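Halogen swap on the aryl ring of the series

The source may report more compounds than this note shows. Statements on the series, on what has been measured and on what is new or still open speak of the compounds shown alone.

Compound 1, `N#Cc1c(-c2ccc(F)c(Br)c2)no[n+]1[O-]`: in an assay on isolated protein for inhibition of glutathione reductase, mitochondrial (Homo sapiens), using NADPH, with a stated time of 15 min (on this read-out higher numbers stand for weaker inhibition and lower numbers for stronger inhibition), compound 1 gives > 50000 nM, a limit of the assay.
Compound 2, `N#Cc1c(-c2cccc(Br)c2)no[n+]1[O-]`: in this assay compound 2 gives > 50000 nM, again a limit of the assay.

Going by the values given here, compound 2 stands at the limit of this assay, and the only other value shown does the same, both sitting at the limit of > 50000 nM in this assay, at which 2 of the 2 values shown sit. Among the compounds with values here, the single measured step, a step that the two limits leave unreadable from compound 1 to compound 2, is therefore of unreadable size. Compound 3, `N#Cc1c(-c2cccc(Cl)c2)no[n+]1[O-]`, is not yet measured; it differs from compound 2 by chloro in place of bromo on an aromatic carbon. Within the data shown here, no measured step concerns a bromo-to-chloro exchange, and the one step available, a step that the two limits leave unreadable from compound 1 to compound 2, gives no readable size to lean on. The expectation for this assay is therefore no change beyond the scatter, with compound 3 most likely reported again as a limit. Compound 3 is estimated at 100000 nM, with a range from 30000 nM to 500000 nM. This estimate corresponds to an expected step that the limit leaves unreadable from compound 2 to compound 3.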

Compound 3, half-maximal inhibitory concentration: 35700 nM
Beside the measured number, compound 3's estimate is 2.8-fold (0.45 log units) above it; the range from low to high includes it.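

Chloro in place of bromo on this aromatic carbon brings the series inside the readable range of this assay for the first time, with compound 3 at 35700 nM. The change amounts to an at least 1.4-fold lower number from compound 2 to compound 3 (0.14 log units; that floor lies within the scatter), so only a lower bound on its size is known, and the true size may be larger. Compound 3 is thus the only fixed point so far, and the other values remain limits: the limit of > 50000 nM in this assay, at which 2 of the 3 values shown sit.

Going by these compounds, the step between the two bromo compounds still cannot be read, so whether the fluoro of compound 1 would alter the reading in the chloro compound remains open. Also open, on these data alone, is how an amine, a carboxylic acid or a methyl group on this aromatic carbon would read against compound 3.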